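A Methyl on the Pyridine Ether of Compound 3

A few compounds are considered here, and "the series" means these few. Any claim that something is new, unique, unknown or untested is made for them only; others in the source may bear on it.

Compound 1, `Cc1ccc(Oc2ccc3nc(COc4cccc(C(=O)O)c4)n(C)c3n2)cc1`: in an ADME assay for permeability, using PAMPA, with a stated time of 4 h (on this read-out lower numbers stand for lower permeability and higher numbers for higher permeability), compound 1 gives 12.6 10^-6 cm/s.
Compound 2, `Cn1c(COc2cccc(C(=O)O)c2)nc2ccc(Oc3ccc4c(c3)CCC4)nc21`: in this assay compound 2 gives 31.5 10^-6 cm/s.
Compound 3, `Cn1c(COc2cccc(C(=O)O)c2)nc2ccc(Oc3ccccn3)cc21`: in this assay compound 3 gives 2.2 10^-6 cm/s.

Compound 3 stands lowest of these three numbers in this assay. Compound 1 is its nearest neighbour and compound 2 the furthest, both separated from compound 3 by more than the usual scatter. Among the compounds with values here, the only measured step between neighbours is a 2.5-fold higher number from compound 1 to compound 2 (0.40 log units; beyond the scatter), which exchanges one ring for another on the ether oxygen.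

Compound 4, `Cc1cccnc1Oc1ccc2nc(COc3cccc(C(=O)O)c3)n(C)c2c1`, differs from compound 3 by methyl in place of hydrogen on an aromatic carbon. Within the data shown here, this is a different kind of change from the one measured in the step from compound 1 to compound 2, so no measured step bears directly on it, and the data give no precedent for adding a methyl to the pyridine ring. The author therefore expects only a small step in this assay, a 1.8-fold higher number from compound 3 to compound 4 (0.26 log units; within the scatter), upward but possibly within the scatter. Compound 4 is estimated at 4 10^-6 cm/s in this assay, with a range from 1.5 10^-6 cm/s to 10 10^-6 cm/s.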

Compound 4, apparent permeability: 6 10^-6 cm/s
Compound 4: middle estimate off by 1.5-fold (0.18 log units), on the low side; the range from low to high includes it.
By their numbers in this assay, from the lowest: compound 3; then compound 4; then compound 1; then compound 2.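

The change from compound 3 to compound 4 puts methyl in place of hydrogen on an aromatic carbon of the pyridin-2-yl group, ortho to a large group and two atoms from the ring nitrogen, and in this assay it gives a 2.7-fold higher number from compound 3 to compound 4 (0.44 log units; beyond the scatter) as a modest step beyond the scatter. The earlier compounds shown here showed only an exchange of one whole ring for another on the ether oxygen, whereas this step shows that the read-out also responds to an addition of 1 heavy atom, with no ring and no hydrogen-bond donors or acceptors, on the ring already present in compound 3. Nothing among the data shown explains why the number rises at this position.

On these data alone, it remains open whether an ethyl, a methoxy or an amine on the same aromatic carbon would raise the number further, leave it unchanged or lower it. As far as these compounds go, it is also open whether methyl would give a step of similar size of compound 1 and compound 2, which carry other rings on the ether oxygen.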